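Octyl to 4-fluorophenoxy exchange in the chloro-substituted analogue

The source may hold more compounds than are shown below. What is called first, only, known or untested is meant among the compounds shown, and "the series" means these compounds.

Compound 1 `CCCCCCCCc1ccc(OC(C)C(=O)Cn2nnc(-c3ccccc3)n2)cc1` gives 24 nM in an assay on microsomes from brain for inhibition of Fatty-acid amide hydrolase 1 (Rattus norvegicus), read by fluorescence and HPLC, with a stated time of 60 min; a lower number here means a stronger inhibitor, a higher number a weaker inhibitor. Compound 2 `CC(Oc1ccc(Oc2ccc(F)cc2)cc1)C(=O)Cn1nnc(-c2ccccc2)n1` gives 24 nM in this assay, and the step of no change at the digits printed from compound 1 to compound 2 (within the scatter). Compound 3 `CCCCCCCCc1ccc(OC(C)C(=O)Cn2nnc(-c3ccc(Cl)cc3)n2)cc1` gives 35 nM in this assay, the highest of the three numbers, although its gaps to compound 1 and to compound 2 both lie within the scatter, as does the step of a 1.5-fold higher number from compound 1 to compound 3 (0.16 log units; within the scatter). Compound 4 `CC(Oc1ccc(Oc2ccc(F)cc2)cc1)C(=O)Cn1nnc(-c2ccc(Cl)cc2)n1` is not yet measured; it differs from compound 3 by 4-fluorophenoxy in place of octyl on an aromatic carbon. The same exchange has been made once already, as the step of no change at the digits printed from compound 1 to compound 2 (within the scatter), which left the number unchanged. On that basis compound 4 is expected to show no change at the digits printed from compound 3 to compound 4 (within the scatter), no change beyond the scatter. The estimate for compound 4 in this assay is 35 nM, with a range from 15 nM to 80 nM.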

Compound 4, half-maximal inhibitory concentration: 42 nM
The estimate for compound 4 lay 1.2-fold (0.08 log units) below the measured number; measured number inside the range.
By their numbers in this assay, from the lowest: compounds 1, 2, 3 and 4 (each within the scatter of the next).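

In this assay, the exchange of octyl for 4-fluorophenoxy now reads on a second core, the chloro-bearing one, with the step of a 1.2-fold higher number from compound 3 to compound 4 (0.08 log units; within the scatter), and it matches the earlier result: the same change on two cores in this assay, no change at the digits printed (within the scatter) from compound 1 to compound 2 and a 1.2-fold higher number (0.08 log units; within the scatter) from compound 3 to compound 4, 1.2-fold (0.08 log units) apart, within the scatter of two such steps. Chloro in place of hydrogen can also now be read on the 4-fluorophenoxy core, with the step of a 1.8-fold higher number from compound 2 to compound 4 (0.24 log units; within the scatter), and it matches the step on the octyl core: the same change on two cores in this assay, a 1.5-fold higher number (0.16 log units; within the scatter) from compound 1 to compound 3 and a 1.8-fold higher number (0.24 log units; within the scatter) from compound 2 to compound 4, 1.2-fold (0.08 log units) apart, within the scatter of two such steps. Neither change has a step beyond the scatter in these four compounds.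

On these data alone, it stays open whether an amine, a carboxylic acid or a shorter chain such as butyl on this aromatic carbon would leave the number in this range.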